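The source may hold more compounds than are shown below. What is called first, only, known or untested is meant among the compounds shown, and "the series" means these compounds.

Of the compounds shown here, three on a shared core have been measured in a functional assay on PC-3 cells (Homo sapiens) for cytotoxicity, read by MTT assay, with a stated time of 72 h; on this read-out lower numbers stand for stronger inhibition and higher numbers for weaker inhibition. Compound 1 `COc1ccc(S(=O)(=O)c2nc3ccccc3nc2Nc2ccc(N)cc2)cc1` gives 9640 nM. Compound 2 `COc1ccc(Nc2nc3ccccc3nc2S(=O)(=O)c2ccc(F)cc2)cc1` gives 4330 nM, and compound 3 `COc1cc(Nc2nc3ccccc3nc2S(=O)(=O)c2ccc(F)cc2)cc(OC)c1` gives 4530 nM. Compound 3 stands second highest of the three, nearest to compound 2 and furthest from compound 1, the latter gap being beyond the scatter. Within the data shown here, the one measured step, a 1.0-fold higher number from compound 2 to compound 3 (0.02 log units; within the scatter), lies within the scatter.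

Compound 4 `Nc1ccc(Nc2nc3ccccc3nc2S(=O)(=O)c2ccc(F)cc2)cc1` has not yet been measured. It differs from compound 3 in one place: 4-aminophenyl in place of 3,5-dimethoxyphenyl on a nitrogen on an aromatic ring. Among the measured compounds shown here, no measured step makes this exact change on this partner; the only step at this position exchanged one group for another and barely moved the number. Like compound 4, compound 1 carries 4-aminophenyl on that nitrogen, though with a different group elsewhere in the molecule, and compound 1 gives 9640 nM, the highest number of the three. The expected step is therefore a 1.5-fold higher number from compound 3 to compound 4 (0.19 log units; within the scatter), toward a higher number. Compound 4 is thus estimated at 7000 nM in this assay, with a range from 3000 nM to 16000 nM.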

Compound 4, half-maximal inhibitory concentration: 2050 nM
The estimate for compound 4 lay 3.4-fold (0.53 log units) above the measured number; measured number outside the range, below it.
By their numbers in this assay, from the lowest: compound 4; then compounds 2 and 3 (each within the scatter of the next); then compound 1.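

In this assay, this position proves responsive after all: where the earlier exchange of methoxy-bearing rings left the number flat, 4-aminophenyl in place of 3,5-dimethoxyphenyl gives a 2.2-fold lower number from compound 3 to compound 4 (0.34 log units; beyond the scatter). Amino in place of methoxy on an aromatic carbon gives a step of similar size, a 2.1-fold lower number from compound 2 to compound 4 (0.32 log units; beyond the scatter), so the 4-aminophenyl group gives the lowest number at this position among compounds 2, 3 and 4. The high number of compound 1 does not belong to its 4-aminophenyl group, as fluoro in place of methoxy on an aromatic carbon, with that group kept, gives a 4.7-fold lower number from compound 1 to compound 4 (0.67 log units; beyond the scatter).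

Going by these compounds, whether a hydroxy, a dimethylamino or an acetamido group on that aromatic carbon would match amino remains open. Nothing available bears on what lies behind these steps.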